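Thioether cap variation on the benzamide series in HeLa cells

A few compounds are considered here, and "the series" means these few. Any claim that something is new, unique, unknown or untested is made for them only; others in the source may bear on it.

Compound 1 has the structure `Nc1ccccc1NC(=O)c1ccc(CSc2cccc(F)c2)cc1`. Among the measured compounds shown here, in a functional assay on HeLa cells (Homo sapiens) for antiproliferative activity, read by CCK-8 assay, with a stated time of 72 h (on this read-out higher numbers stand for weaker inhibition and lower numbers for stronger inhibition), compound 1 gives 3240 nM; it is the only compound of the series with a number in this assay. Compound 2, with the structure `CC(C)(C)c1ccc(SCc2ccc(/C=C/C(=O)Nc3ccccc3N)cc2)cc1`, has in this assay the entry "not determined" (no result reported), which is no number, so it offers no comparison.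

Compound 3, with the structure `Nc1ccccc1NC(=O)c1ccc(CSCCc2ccccc2)cc1`, is yet to be measured in this assay. Its difference from compound 1 is phenethyl in place of 3-fluorophenyl on a sulfur. The shared core is otherwise unchanged.

For the measured compounds named here, no step between two measured compounds is available in this assay, so the effect of swapping the group on the sulfur cannot be read from any prior pair here. The expectation is therefore anchored to compound 1 alone, with a step expected to stay within the usual scatter, in no clear direction.

Compound 3 is expected to give 3500 nM in this assay, with a plausible range from 1200 nM to 10000 nM. This means an expected step of a 1.1-fold higher number from compound 1 to compound 3 (0.03 log units; within the scatter), which is not expected to exceed the scatter.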

Compound 3, half-maximal inhibitory concentration: 6430 nM
Compound 3: the middle estimate sits 1.8-fold (0.26 log units) below what was measured; the measured number falls inside the stated range.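

In this assay, the group on the sulfur now has its first readable step: phenethyl in place of 3-fluorophenyl gives a 2.0-fold higher number from compound 1 to compound 3 (0.30 log units; within the scatter) and so stays within the usual scatter of the read-out. This exchange removes the fluorine, adds a saturated chain and goes from 7 heavy atoms to 8, yet this single pair does not separate compound 1 from compound 3 in antiproliferative activity. No independent measurement is available to explain how the two compounds compare.

The step joins two differences, the fluorine and the chain, and a plain phenyl group on the sulfur would be needed to read them apart. As far as these compounds go, it also remains open whether a longer chain on the sulfur, or a cap carrying an amine or a carboxylic acid, would move the number beyond the scatter in either direction.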